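A Methyl Group Enters Where Substituents Seem to Matter

The compounds below may be only part of what the source reports. "The series", "measured", "known", "first", "only" and "open" are said of these compounds alone.

Compound 1 `CC(C)c1ccc(-c2nc(SCc3cn(CC(=O)NC(=O)Nc4ccccn4)nn3)nc(Nc3ccccc3Cl)c2C#N)cc1`: 23400 nM
Compound 2 `CC(C)c1ccc(-c2nc(SCc3cn(CC(=O)NC(=O)Nc4ccccn4)nn3)nc(Nc3cccc(C(F)(F)F)c3)c2C#N)cc1`: 24200 nM
Compound 3 `CC(C)c1ccc(-c2nc(SCc3cn(CC(=O)NC(=O)Nc4ccccn4)nn3)nc(Nc3ccccc3)c2C#N)cc1`: > 64000 nM, a limit of the assay rather than a number

In a functional assay on ECa-109 cells (Homo sapiens) for inhibition, read by MTT assay, with a stated time of 72 h (on this read-out lower numbers stand for stronger inhibition and higher numbers for weaker inhibition), compound 3 stands apart from the other two: its value is the limit of > 64000 nM in this assay, at which 1 of the 3 values shown sits. Compound 4 (`Cc1cccc(Nc2nc(SCc3cn(CC(=O)NC(=O)Nc4ccccn4)nn3)nc(-c3ccc(C(C)C)cc3)c2C#N)c1`) differs from compound 3 by methyl in place of hydrogen on an aromatic carbon. Among the compounds with values here, two measured steps bear on this. In this assay, an at least 2.7-fold higher number from compound 1 to compound 3 (0.43 log units; beyond the scatter), and an at least 2.6-fold higher number from compound 2 to compound 3 (0.42 log units; beyond the scatter), so stripping a group from that ring weakened inhibition both times. Putting a methyl back runs the other way, so a lower number is expected for compound 4, though a methyl is smaller than chloro or trifluoromethyl and the size of the gain is uncertain. Compound 4 is therefore estimated at 40000 nM, between 15000 nM and 100000 nM, an expected step of an at least 1.6-fold lower number from compound 3 to compound 4 (0.20 log units; that floor lies within the scatter).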

Compound 4, half-maximal inhibitory concentration: 7320 nM
The estimate for compound 4 lay 5.5-fold (0.74 log units) above the measured number, outside the stated range (below it).
By their numbers in this assay, from the lowest: compound 4; then compounds 1 and 2 (each within the scatter of the next). At a limit, above all of these: compound 3.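

On this ring, methyl does more than recover what the bare phenyl lost: in this assay there is an at least 8.7-fold lower number from compound 3 to compound 4 (0.94 log units; beyond the scatter). Compound 3 holds a limit, not a true number: the limit of > 64000 nM in this assay, at which 1 of the 4 values shown sits. Methyl also outdoes the two larger groups, with a 3.3-fold lower number from compound 2 to compound 4 (0.52 log units; beyond the scatter) and a 3.2-fold lower number from compound 1 to compound 4 (0.50 log units; beyond the scatter), so among these compounds a bigger group is not needed for the gain.

Still open, going by these compounds, is whether the gain is specific to methyl or would also come with an ethyl chain, a methoxy group or an amine at the same place.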